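A few compounds are considered here, and "the series" means these few. Any claim that something is new, unique, unknown or untested is made for them only; others in the source may bear on it.

In an ADME assay on liver (Rattus norvegicus, strain Wistar) for metabolic stability, read by HPLC, tested at 200 uM (on this read-out higher numbers stand for a longer-lived compound and lower numbers for a shorter-lived compound), compound 1, with the structure `Cc1cc(OC(=O)c2ccc(OCCCO[N+](=O)[O-])cc2)n(-c2ccccc2)n1`, gives only a limit of the assay, < 0.0167 h. Compound 2, with the structure `Cc1cc(OC(=O)c2ccc(CC(CO[N+](=O)[O-])O[N+](=O)[O-])cc2)n(-c2ccccc2)n1`, likewise gives only a limit, < 0.0167 h. Compound 2 thus stands at the limit of < 0.0167 h in this assay, at which 2 of the 2 values shown sit, not at a measured number. Compound 3, with the structure `Cc1cc(OC(=O)c2ccc(CCCO[N+](=O)[O-])cc2)n(-c2ccccc2)n1`, differs from compound 2 in one place: hydrogen in place of nitrooxy on a saturated chain carbon bound to two saturated chain carbons. Cut one bond further out, the same change reads as a 1,2-bis(nitrooxy)ethyl chain becoming a 2-(nitrooxy)ethyl chain. Among the measured compounds shown here, no measured step between two compounds is available to guide an expectation, so the expected change is a step that the limit leaves unreadable from compound 2 to compound 3, no move beyond the usual scatter. Compound 3 is therefore estimated to give 0.01 h in this assay, with a range from 0.003 h to 0.03 h, and it is expected that the assay again reports only a limit rather than a number.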

Compound 3, half-life in the liver assay: < 0.0167 h
Compound 3: no number, only a limit; the forecaster's own chance of this, stated with the estimate: 85%; the middle value does not contradict the limit.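

No new step can be read from compound 1, compound 2 and compound 3 in the liver assay, where each gives only a limit: the limit of < 0.0167 h in the liver assay, at which 3 of the 3 values shown sit.

In a physicochemical assay for metabolic stability, read by HPLC (on this read-out higher numbers stand for a longer-lived compound and lower numbers for a shorter-lived compound), compound 2 gives 8 h and compound 3 gives 13 h. In the physicochemical assay that is a 1.6-fold higher number from compound 2 to compound 3 (0.21 log units; within the scatter).

The compounds shown leave open how long each one actually lasts in the liver assay.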